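Cyclohexyl in Place of Propyl on the Chain Carbon

This account rests on a few compounds, and the source may have more. Where it says the series, first, only, none or still open, it means among the compounds named here.

compound 1 `Oc1nnc(-c2cccnc2)c2ccccc12`: 26%
compound 2 `CCCCn1nc(-c2cccnc2)c2ccccc2c1=O`: 91%

In an assay on isolated protein (Oryctolagus cuniculus) with Thromboxane-A synthase (Homo sapiens) as the target, tested at 1 uM (a higher number here means more inhibition at the concentration tested (going by the name of the read-out), a lower number less inhibition), compound 1 gives 26%, while compound 2 gives 91%, the higher of the two and beyond the scatter from compound 1. Compound 3 `O=c1c2ccccc2c(-c2cccnc2)nn1CC1CCCCC1` has not yet been measured. It differs from compound 2 in one place: cyclohexyl in place of propyl on a saturated chain carbon bound to an aromatic nitrogen. Within the data shown here, no measured pair shows this change. Compound 3 is expected to stay close to compound 2, because compound 2 gives 91%, with an expected step of a number 6 percentage points lower from compound 2 to compound 3 (within the scatter), not beyond the scatter. The estimate for compound 3 is 85%, in a range from 65% to 97%.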

Compound 3, a percentage reported as inhibition, at one concentration (the size of the read-out at that concentration, not a potency): 98%
Beside the measured number, compound 3's estimate is 13 percentage points below it, outside the stated range (above it).
By their numbers in this assay, from the lowest: compound 1; then compounds 2 and 3 (each within the scatter of the next).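

In this assay the change from an open chain to a six-membered non-aromatic ring of carbon only gives a number 7 percentage points higher from compound 2 to compound 3 (within the scatter). This position on the chain therefore accepts cyclohexyl as well as propyl, and compound 2 and compound 3 cannot be ordered here. No evidence at hand bears on this result. The compounds shown leave open whether an amine or a carboxylic acid at this position would hold the inhibition seen with these carbon-only groups. They also leave open how a longer chain would fare.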